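A few compounds are considered here, and "the series" means these few. Any claim that something is new, unique, unknown or untested is made for them only; others in the source may bear on it.

Of the compounds shown here, three sharing one core have been measured in a functional assay on the whole organism for inhibition, with Rattus norvegicus as the target, at a dose of 3 mg/kg by the oral route; on this read-out higher numbers stand for a stronger effect at the one dose given and lower numbers for a weaker effect. Compound 1, with the structure `CCCCOc1cccc(C(=O)Nc2nn[nH]n2)n1`, gives 18% in this assay. Compound 2, with the structure `Cc1ccc(C)c(C(=O)Nc2nn[nH]n2)n1`, gives 65%, and compound 3, with the structure `Cc1ccnc(C(=O)Nc2nn[nH]n2)c1`, gives 42%. Compound 1 thus stands lowest of the three, and both of its gaps, to compound 3 and to compound 2, lie beyond the usual scatter of this assay.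

Compound 4, with the structure `O=C(Nc1nn[nH]n1)c1cccc(Br)n1`, has not yet been measured. Compared with compound 1 it carries the change (bromo in place of butoxy on an aromatic carbon), so the butoxy group on the aromatic carbon next to the ring nitrogen is replaced by bromo. Going by the values given here, with only three measured compounds and no single-point step among them, the direction of this change can only be inferred from the higher values of compound 2 and compound 3, which carry smaller groups than compound 1.

On that basis compound 4 is expected to show a rise of a number 22 percentage points higher from compound 1 to compound 4 (beyond the scatter) in this assay. The estimated value for compound 4 is 40%, in a range from 15% to 65%.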

Compound 4, a percentage reported as inhibition, in the whole organism at one dose (the size of the read-out at that dose, not a potency): 38%
Compound 4: middle estimate off by 2 percentage points, on the high side, within the range that was stated.
By their numbers in this assay, from the lowest: compound 1; then compounds 4 and 3 (each within the scatter of the next); then compound 2.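

In this assay, bromo in place of butoxy on an aromatic carbon, next to the ring nitrogen, gives a number 20 percentage points higher from compound 1 to compound 4 (beyond the scatter). Going by these compounds alone, this is the first step that changes only one place, and it shows that the read-out responds to the group at this position on the shared core. It also ties the low value of compound 1 in part to its butoxy group, although no measured property accompanies the step that could explain the change.

The compounds shown leave open whether the rise comes from losing the butoxy chain or from gaining bromo. They also do not show how a methoxy group, a chloro group or an amine at this position would compare with either one.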